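The source may hold more compounds than are shown below. What is called first, only, known or untested is meant among the compounds shown, and "the series" means these compounds.

In an ADME assay on Vero cells (Chlorocebus sabaeus) for cytotoxicity, read by MTT assay (on this read-out lower numbers stand for stronger inhibition and higher numbers for weaker inhibition), compound 1 `C=CCOc1cc(OC)c(C(=O)/C=C/c2ccc(C(F)(F)F)cc2)c(OCC=C)c1` with trifluoromethyl gives 7200 nM and stands lowest of the three measured compounds. Compound 2 `C=CCOc1cc(OC)c(C(=O)/C=C/c2ccc(C)cc2)c(OCC=C)c1` with methyl gives 211000 nM as the highest number. Compound 3 `C=CCOc1cc(OC)c(C(=O)/C=C/c2ccc(OC)cc2)c(OCC=C)c1` with methoxy gives 99900 nM and so holds the middle place, much nearer to compound 2 than to compound 1.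

Compound 4 `C=CCOc1cc(OC)c(C(=O)/C=C/c2ccc(Cl)cc2)c(OCC=C)c1` differs from compound 3 by chloro in place of methoxy on an aromatic carbon, para to a large group, with chloro in place of methoxy on an aromatic carbon as the counted change. Within the data shown here, no chloro compound has been measured yet, but three steps at this same place bear on it. The step of a 2.1-fold lower number from compound 2 to compound 3 (0.32 log units; beyond the scatter) is modest, while a 29-fold higher number from compound 1 to compound 2 (1.47 log units; beyond the scatter) and a 14-fold higher number from compound 1 to compound 3 (1.14 log units; beyond the scatter) are large. Only compound 1 carries halogen atoms there, so the number is expected to fall, though by less than the large 14-fold higher number from compound 1 to compound 3 (1.14 log units; beyond the scatter) for that compound.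

The expected step is a 2.9-fold lower number from compound 3 to compound 4 (0.46 log units; beyond the scatter) and thus moderate in size. Compound 4 is estimated at 35000 nM with an expected range of 12000 nM to 100000 nM on this read-out.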

Compound 4, half-maximal inhibitory concentration: 10400 nM
Compound 4: middle estimate off by 3.4-fold (0.53 log units), on the high side, outside the stated range (below it).
By their numbers in this assay, from the lowest: compounds 1 and 4 (each within the scatter of the next); then compound 3; then compound 2.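

In this assay, the change from 4-methoxyphenyl to 4-chlorophenyl gives a 9.6-fold lower number from compound 3 to compound 4 (0.98 log units; beyond the scatter), and chloro in place of methyl gives a 20-fold lower number from compound 2 to compound 4 (1.31 log units; beyond the scatter), so a low number at this position is not unique to trifluoromethyl. The step of a 1.4-fold higher number from compound 1 to compound 4 (0.16 log units; within the scatter) lies within the scatter, so chloro and trifluoromethyl cannot be told apart here, and among these four compounds the two halogen-bearing groups stand clearly apart from methyl and methoxy, with no compound going against that split. Nothing available here explains this split.

On these data alone, it remains open whether bromo, fluoro, a nitrile or an amine at this position would fall with chloro and trifluoromethyl or with methyl and methoxy. As far as these compounds go, it is also open whether the chloro change would have the same effect on a different core.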